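The source may hold more compounds than are shown below. What is called first, only, known or untested is meant among the compounds shown, and "the series" means these compounds.

Measured so far in an assay on isolated protein for binding affinity to somatostatin receptor type 1 (Homo sapiens); a higher number here means weaker binding, a lower number tighter binding:
compound 1, `COC(=O)c1cc(CC(C)CN2C[C@H]3CCCC[C@H]3[C@@H](C(=O)N3CCN(c4ccc([N+](=O)[O-])cc4)CC3)C2)cc(C(=O)OC)c1` — 2340 nM
compound 2, `COC(=O)c1cc(CC(C)CN2C[C@@H]3CCCC[C@@H]3[C@H](C(=O)N3CCN(c4ccc([N+](=O)[O-])cc4)CC3)C2)cc(C(=O)OC)c1` — 398 nM
compound 3, `Cc1nc2cc(C[C@H](C)CN3C[C@@H]4CCCC[C@@H]4[C@H](C(=O)N4CCN(c5ccc(F)c(F)c5)CC4)C3)ccc2o1` — 1380 nM

Compound 3 sits with the second highest number of the three. Its number and that of compound 1 lie within the usual scatter of each other, while compound 2 gives a clearly lower number than compound 3. Among the compounds with values here, the one step measured between two compounds is a 5.9-fold lower number from compound 1 to compound 2 (0.77 log units; beyond the scatter), and the only thing that can be said about it is the fact that one of compounds 1 and 2 is drawn with a defined configuration and the other without, at the place where they differ.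

Compound 4, `C[C@@H](Cc1ccc2nccnc2c1)CN1C[C@@H]2CCCC[C@@H]2[C@H](C(=O)N2CCN(c3ccc(F)c(F)c3)CC2)C1`, is compound 3 with one change: quinoxalin-6-yl in place of 2-methyl-1,3-benzoxazol-5-yl on a saturated chain carbon, three bonds along the chain from an amine nitrogen in a ring. Within the data shown here, no measured step in this set touches that part of the molecule, since the step from compound 1 to compound 2 concerns only the drawn configuration of the shared core, so nothing here tells how the swap of one bicyclic aromatic group for another should move the number. In this assay the estimate for compound 4 therefore stays close to compound 3, with a step of a 1.2-fold lower number from compound 3 to compound 4 (0.06 log units; within the scatter) expected, not beyond the scatter, and a wide range on either side. Compound 4 is estimated at 1200 nM, between 350 nM and 4000 nM.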

Compound 4, dissociation constant: 2630 nM
Compound 4: the middle estimate sits 2.2-fold (0.34 log units) below what was measured; the measured number falls inside the stated range.
By their numbers in this assay, from the lowest: compound 2; then compounds 3, 1 and 4 (each within the scatter of the next).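

In this assay, quinoxalin-6-yl in place of 2-methyl-1,3-benzoxazol-5-yl on a saturated chain carbon, three bonds along the chain from an amine nitrogen in a ring, gives a 1.9-fold higher number from compound 3 to compound 4 (0.28 log units; within the scatter) and so does not separate the two groups. Within the data shown here, this is the first measured step at this position, since the earlier compounds showed only a change in the drawn configuration of the shared core, and it shows that one bicyclic aromatic group can stand in for the other without a shift beyond the scatter. Nothing recorded here bears on the reason for this result.

Both groups are bicyclic aromatic groups, so the compounds leave open how a plain phenyl, a cyclohexyl, an amine or a carboxylic acid would read at this place. They also leave open whether a longer chain would change the picture.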